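The compounds below may be only part of what the source reports. "The series", "measured", "known", "first", "only" and "open" are said of these compounds alone.

Three measured compounds share the core seen in compound 1 `CN(C)CCn1ccc2ccc(NS(=O)(=O)c3c(Cl)nc4sccn34)cc21`, which in an assay on HEK293 cells for binding affinity to 5-hydroxytryptamine receptor 6 (Homo sapiens) (on this read-out lower numbers stand for stronger inhibition and higher numbers for weaker inhibition), gives 55.2 nM. Compound 2 `Cc1c(S(=O)(=O)Nc2ccc3ccn(CCN(C)C)c3c2)sc2ccc(Cl)cc12` gives 90.2 nM in this assay, and compound 3 `CN(C)CCn1ccc2ccc(NS(=O)(=O)CCc3cccc4ccccc34)cc21` gives 74.5 nM. Compound 2 has the highest of the three numbers, but its gaps to compound 3 and to compound 1 both lie within the scatter, so no order among the three can be read from them. Among the measured compounds shown here, no step between measured compounds that differ in one place is available, so the effect of a single change on this read-out is not yet known for the series.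

Compound 4 `Cc1c(S(=O)(=O)Nc2ccc3cc(C)n(CCN(C)C)c3c2)sc2ccc(Cl)cc12` differs from compound 2 by methyl in place of hydrogen on an aromatic carbon. For the measured compounds named here, with no single-point step on record to compare against, a step of no size beyond the scatter in this assay is expected. The expected step from compound 2 to compound 4 is a 1.1-fold lower number from compound 2 to compound 4 (0.05 log units; within the scatter). For compound 4 the estimate in this assay is 80 nM, with a range from 30 nM to 250 nM.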

Compound 4, inhibition constant: > 1000 nM
Compound 4: only a limit was reported (the forecaster's own chance of this, stated with the estimate: 2%); middle value at least 12-fold (1.09 log units) from the limit.
By their numbers in this assay, from the lowest: compounds 1, 3 and 2 (each within the scatter of the next). At a limit, above all of these: compound 4.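

Among the compounds shown here, this is the first step that isolates one place: methyl in place of hydrogen on an aromatic carbon, next to the ring nitrogen and next to the ring atom that bears the 2-(dimethylamino)ethyl group, gives an at least 11-fold higher number from compound 2 to compound 4 (1.04 log units; beyond the scatter) in this assay. The position is therefore sensitive to substitution, since an entering group of only 1 heavy atom, with no net charge, moves the read-out well beyond the scatter. For compound 4 the reported figure is a limit, so the step has a lower bound but no exact size: the limit of > 1000 nM in this assay, at which 1 of the 4 values shown sits.

As far as these compounds go, whether a fluorine atom or an ethyl group on this same carbon would give a similar step remains open. Also open, from the compounds shown here alone, is whether this methyl has the same effect alongside the sulfonamide groups of compound 1 or compound 3, and the data do not give the cause of the step.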